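A few compounds are considered here, and "the series" means these few. Any claim that something is new, unique, unknown or untested is made for them only; others in the source may bear on it.

Measured so far:
compound 1, `CC(C)(NC(=O)OCc1ccccc1)c1nc(O)c(O)c(NC(=O)NCc2ccc(F)cc2)n1`, in an ADME assay on C8166 cells (Homo sapiens) for cytotoxicity, read by MTT assay, with a stated time of 3 days; on this read-out lower numbers stand for higher toxicity in this test and higher numbers for lower toxicity in this test: 81100 nM
compound 2, `CC(C)(NC(=O)OCc1ccccc1)c1nc(O)c(O)c(C(=O)NN)n1`, in this assay: > 500000 nM

Compound 1 holds the only numerical result in this assay; the other entry is not a number. For compound 2 the result of > 500000 nM in this assay is a limit of the test and no measurement. That position is summed up in the limit of > 500000 nM in this assay, at which 1 of the 2 values shown sits. For the measured compounds named here, no step between two measured compounds can be drawn from these two entries, so nothing is known about how much a single structural change shifts the read-out in this assay within this pair.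

Compound 3, `COc1ccc(CNC(=O)Nc2nc(C(C)(C)NC(=O)OCc3ccccc3)nc(O)c2O)cc1`, is not yet measured. It differs from compound 1 by methoxy in place of fluoro on an aromatic carbon of the six-membered carbon ring, para to a large group.

In the absence of any measured step, the expected step from compound 1 to compound 3 is small, of about a 1.2-fold lower number from compound 1 to compound 3 (0.06 log units; within the scatter), with no direction beyond the scatter. Compound 3 is expected near 70000 nM in this assay, with a range from 25000 nM to 200000 nM.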

Compound 3, half-maximal cytotoxic concentration: > 500000 nM
Compound 3: no number, only a limit (the forecaster's own chance of this, stated with the estimate: 15%); middle value at least 7.1-fold (0.85 log units) from the limit.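

In this assay, methoxy in place of fluoro on an aromatic carbon, para to a large group, gives an at least 6.1-fold higher number from compound 1 to compound 3 (0.78 log units; beyond the scatter), so a change at this position alone can move the read-out beyond the scatter, towards lower toxicity in this test. On these data alone, the result for compound 3 is a limit of the test and not a number, so the step gives only a minimum size and its full extent stays unknown. Compound 1 is now the only compound in the series with a numerical result, and the other entries are limits: the limit of > 500000 nM in this assay, at which 2 of the 3 values shown sit.

For the compounds shown here, the data cannot separate the loss of fluoro from the entry of methoxy as the source of the step, and they give no ranking among the compounds at the limit. As far as these compounds go, what chloro, hydroxy or an amine on the same aromatic carbon would give remains open, as does whether ethoxy, with its longer chain, would stay at the limit like methoxy.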